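Swapping a selenium substituent for an amino group

The compounds below may be only part of what the source reports. "The series", "measured", "known", "first", "only" and "open" are said of these compounds alone.

Compound 2 `C[Se]c1nc([Se]C)c2cccnc2n1` has no number in a functional assay on HTB-54 cells (Homo sapiens) for cytotoxicity, read by MTT assay, with a stated time of 72 h; a lower number here means a stronger inhibitor of growth, a higher number a weaker inhibitor of growth; for compound 2 the result is "not determined" (no result reported). Its near relatives do: compound 1 `CCCCC[Se]c1nc([Se]CCCCC)c2cccnc2n1` gives 15200 nM, and compound 3 `CSc1nc(NCc2ccc([Se]C)cc2)c2ccccc2n1` gives 57000 nM, so both are weak inhibitors of growth. Compound 4 `C[Se]c1nc(N)c2cccnc2n1` differs from compound 2 in one place: one nitrogen atom in place of a group of 2 heavy atoms (1 carbon, 1 selenium; no ring), on an aromatic carbon, the amino group entering on an aromatic carbon of a six-membered aromatic ring with 2 nitrogen, part of a fused system of two rings. Among the compounds with values here, with no measured step between these two compounds, the size and direction of the change cannot be read from the data; what can be expected is a weak result in the same broad region as compound 1 and compound 3, possibly reported only as a limit. Compound 4 is expected to give 30000 nM, within a range from 8000 nM to 100000 nM.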

Compound 4, concentration for 50% growth inhibition: 78200 nM
For compound 4 the middle estimate is 2.6-fold (0.42 log units) below the measured one, and the stated range covers the measured number.
By their numbers in this assay, from the lowest: compound 1; then compounds 3 and 4 (each within the scatter of the next).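

No step can be read from compound 4 to compound 2. From the compounds shown here alone, what the amino group does in place of the selenium-bearing group remains open, and no evidence here bears on the result.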